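The compounds below may be only part of what the source reports. "The series", "measured", "known", "first", "only" and "open" are said of these compounds alone.

Compound 1 `O=S(=O)(c1ccccc1)c1nc2ccccc2nc1Nc1ccccc1` gives 590 nM in a functional assay on PC-3 cells (Homo sapiens) for cytotoxicity, read by MTT assay, with a stated time of 72 h; on this read-out higher numbers stand for weaker inhibition and lower numbers for stronger inhibition.
Compound 2 `Nc1ccc(Nc2nc3ccccc3nc2S(=O)(=O)c2ccccc2)cc1` gives 5830 nM in this assay.
Compound 3 `COc1ccc(S(=O)(=O)c2nc3ccccc3nc2Nc2ccccc2)cc1` gives 1260 nM in this assay.

Among these three numbers compound 3 stands second highest. Going by the values given here, the step of a 2.1-fold higher number from compound 1 to compound 3 (0.33 log units; beyond the scatter) separates it from its nearest neighbour, while compound 2, the only number above it, lies furthest away.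

Compound 4 `COc1ccc(S(=O)(=O)c2nc3ccccc3nc2Nc2ccc(N)cc2)cc1` has not yet been measured in this assay. It differs from compound 3 in one place: amino in place of hydrogen on an aromatic carbon. Among the compounds with values here, one measured step bears directly on this: the same change on the same ring was made between compound 1 and compound 2, and the result was a 9.9-fold higher number from compound 1 to compound 2 (0.99 log units; beyond the scatter). Within the data shown here, no other measured pair shows this change, so that single step carries the whole expectation. Applying the same change to compound 3 is therefore expected to give a step of about a 9.5-fold higher number from compound 3 to compound 4 (0.98 log units; beyond the scatter), that is, a markedly higher number and thus weaker inhibition. For compound 4 the expected value in this assay is 12000 nM, with a plausible range from 5000 nM to 30000 nM.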

Compound 4, half-maximal inhibitory concentration: 9640 nM
Estimate against measurement, compound 4: 1.2-fold (0.10 log units) above; the measured number falls inside the stated range.
By their numbers in this assay, from the lowest: compound 1; then compound 3; then compounds 2 and 4 (each within the scatter of the next).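

In this assay, turning anilino into (4-aminophenyl)amino now gives a 7.7-fold higher number from compound 3 to compound 4 (0.88 log units; beyond the scatter), so the loss of activity seen on the core of compound 1 also appears on a second core, and the two steps agree: the same change on two cores in this assay, a 9.9-fold higher number (0.99 log units; beyond the scatter) from compound 1 to compound 2 and a 7.7-fold higher number (0.88 log units; beyond the scatter) from compound 3 to compound 4, 1.3-fold (0.11 log units) apart, within the scatter of two such steps The methoxy change can now also be read with the amino group present, where it gives a 1.7-fold higher number from compound 2 to compound 4 (0.22 log units; within the scatter), and this matches the step without the amino group: the same change on two cores in this assay, a 2.1-fold higher number (0.33 log units; beyond the scatter) from compound 1 to compound 3 and a 1.7-fold higher number (0.22 log units; within the scatter) from compound 2 to compound 4, 1.3-fold (0.11 log units) apart, within the scatter of two such steps Within these four compounds, then, each change keeps about the same size whether or not the other group is present.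

On these data alone, it remains open whether the loss belongs to the amino group in particular or would follow any group at this place on the ring, which a hydroxyl, a chlorine or an acetamide there could help separate. Also open, as far as these compounds go, is whether the amino group gives the same step at another place on that ring.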